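Cytotoxicity limits across the biaryl amide series

The source may report more compounds than this note shows. Statements on the series, on what has been measured and on what is new or still open speak of the compounds shown alone.

Measured compounds:
Compound 1 `CCOC(=O)CCCCCOc1cccc(CN(C(=O)c2ccc(-c3cccc(O)c3)cc2)C(C)C)c1` — in an ADME assay on BJ cells (Homo sapiens) for cytotoxicity, read by CellTiter-Glo and resazurin assay, with a stated time of 72 h (a lower number here means that less compound is needed, a higher number that more compound is needed for the effect), compound 1 gives > 26000 nM, a limit of the assay.
Compound 2 `CCOC(=O)CCCCCOc1cccc(CN(C(=O)c2ccc(-c3cc(OC)ccc3F)cc2)C(C)C)c1` — in this assay compound 2 gives > 26000 nM, also a limit.
Compound 3 `CCOC(=O)CCCCCOc1cccc(CN(C(=O)c2ccc(-c3cccc(Cl)c3)cc2)C(C)C)c1` — in this assay compound 3 gives > 18400 nM, again a limit.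

Compound 3 therefore stands only at the limit of > 18400 nM in this assay, at which 1 of the 3 values shown sits, while the two other values sit at the limit of > 26000 nM in this assay, at which 2 of the 3 values shown sit. None of the three measured steps gives a readable size: a step that the two limits leave unreadable from compound 1 to compound 2, a step that the two limits leave unreadable from compound 1 to compound 3 and a step that the two limits leave unreadable from compound 2 to compound 3 all fall between two limits.

Compound 4 `CCOC(=O)CCCCCOc1cccc(CN(C(=O)c2ccc(Br)cc2)C(C)C)c1` differs from compound 3 as follows: bromo in place of 3-chlorophenyl on an aromatic carbon. Within the data shown here, no measured step involves a change of this kind, so the only bearing comes from the three limits, which show no cytotoxicity reaching the tested concentrations in any member of the series. Compound 4 is therefore expected to return a further limit rather than a number, with a step that the limit leaves unreadable from compound 3 to compound 4 as the step this estimate implies. For compound 4 the estimate in this assay is 26000 nM, within 9000 nM to 60000 nM.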

Compound 4, half-maximal effective concentration: > 26000 nM
Compound 4 gave a limit, no number (the forecaster's own chance of this, stated with the estimate: 70%); the middle value lies on the limit itself.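

In this assay compound 4 gives > 26000 nM, a limit of the assay. The steps to compound 4 from compound 1, compound 2 and compound 3 all fall between two limits, so none can be read. The compounds shown leave open at what concentration, if any, cytotoxicity appears for any of the four.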